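This account rests on a few compounds, and the source may have more. Where it says the series, first, only, none or still open, it means among the compounds named here.

Compound 1 `Cc1cc(C)cc(S(=O)(=O)c2c(C(=O)Nc3ccnc(C#N)c3)[nH]c3ccc(Cl)cc23)c1` gives 6840 nM in an ADME assay on MT4 cells (Homo sapiens) for cytotoxicity, read by MTT assay; on this read-out higher numbers stand for lower toxicity in this test and lower numbers for higher toxicity in this test. Compound 2 `Cc1cc(C)cc(S(=O)(=O)c2c(C(=O)NC(C)C(=O)NCc3ccncc3)[nH]c3ccc(Cl)cc23)c1` gives 19500 nM. Compound 3 `Cc1cc(C)cc(S(=O)(=O)c2c(C(=O)NCC(=O)NCc3ccccc3F)[nH]c3ccc(Cl)cc23)c1` reaches only the limit of this test, > 47300 nM.

Of the two numbers shown, compound 2 has the highest, its nearest neighbour being compound 1 with a 2.9-fold higher number from compound 1 to compound 2 (0.45 log units; beyond the scatter). Compound 4 `Cc1cc(C)cc(S(=O)(=O)c2c(C(=O)NC(C)C(=O)NC(C)c3ccncc3)[nH]c3ccc(Cl)cc23)c1` differs from compound 2 by methyl in place of hydrogen on a saturated chain carbon bound to an amide-type nitrogen and an aromatic carbon. Among the compounds with values here, none of the measured steps tests so small a change: a 2.9-fold higher number from compound 1 to compound 2 (0.45 log units; beyond the scatter), an at least 6.9-fold higher number from compound 1 to compound 3 (0.83 log units; beyond the scatter) and an at least 2.4-fold higher number from compound 2 to compound 3 (0.38 log units; beyond the scatter) each swap one whole group on the amide-type nitrogen. No step beyond the scatter is therefore expected, so the value of compound 4 is estimated at 22000 nM (from 11000 nM to 45000 nM). That expectation means a 1.1-fold higher number from compound 2 to compound 4 (0.05 log units; within the scatter).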

Compound 4, half-maximal cytotoxic concentration: 21900 nM
Compound 4: middle estimate off by 1.0-fold (0.00 log units), on the high side, and the stated range covers the measured number.
By their numbers in this assay, from the lowest: compound 1; then compounds 2 and 4 (each within the scatter of the next). At a limit, above all of these: compound 3.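

Methyl in place of hydrogen on this saturated chain carbon, turning (pyridin-4-yl)methyl into 1-(pyridin-4-yl)ethyl, gives a 1.1-fold higher number from compound 2 to compound 4 (0.05 log units; within the scatter) in this assay. Within the data shown here, the earlier steps each swapped a whole group on the amide-type nitrogen and all lay beyond the scatter, so this is the first sign that a change as small as one methyl at this carbon can leave the read-out within the scatter.

On these data alone, whether an ethyl group, a longer chain or an amine on this carbon would do the same stays open. Compound 3 gives a limit and not a number, so how far it lies from the others also stays open: the limit of > 47300 nM in this assay, at which 1 of the 4 values shown sits.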